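Fluoro Added to Compound 1: Expected Half-Life of Compound 3

The compounds below may be only part of what the source reports. "The series", "measured", "known", "first", "only" and "open" are said of these compounds alone.

Measured so far:
compound 1, `C[C@H](c1ccc(-c2ccccc2-c2nc(=O)o[nH]2)cc1)N(CC1CC1)c1nc2c(C(=O)O)cccc2o1`: 2.6 h
compound 2, `CCCCN(c1nc2c(NS(C)(=O)=O)cccc2o1)[C@H](C)c1ccc(-c2ccccc2-c2nnn[nH]2)cc1`: 4.7 h

Of the compounds shown here, two have been measured in an ADME assay on the whole organism (Macaca fascicularis) for metabolic stability, read by LC-MS, using cassette dosing, at a dose of 1 mg/kg by the oral route; a lower number here means that the compound disappears faster, a higher number that the compound lasts longer. Compound 1 gives 2.6 h, and compound 2 gives 4.7 h. These two numbers lie within the usual scatter of each other, so neither compound stands apart from the other.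

Compound 3 `C[C@H](c1ccc(-c2cc(F)ccc2-c2nc(=O)o[nH]2)cc1)N(CC1CC1)c1nc2c(C(=O)O)cccc2o1` differs from compound 1 in one place only: fluoro in place of hydrogen on an aromatic carbon. For the measured compounds named here, no pair of measured compounds shows what this kind of change does here, so the expectation rests on the change itself being small. The step of a 1.2-fold higher number from compound 1 to compound 3 (0.06 log units; within the scatter) is expected to stay within the scatter, with no clear direction. Compound 3 is therefore estimated at 3 h, with a range from 1.5 h to 6 h.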

Compound 3, half-life: 4.1 h
Estimate against measurement, compound 3: 1.4-fold (0.14 log units) below; measured number inside the range.
By their numbers in this assay, from the lowest: compounds 1, 3 and 2 (each within the scatter of the next).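

Fluoro in place of hydrogen at this aromatic carbon, meta to a large group and para to a group of 6 heavy atoms, now has a measured result: in this assay it gives a 1.6-fold higher number from compound 1 to compound 3 (0.20 log units; within the scatter) for this change. The half-lives of the two compounds therefore cannot be told apart, and this single atom brings no clear gain or loss here. No measurement shown offers an explanation for this result.

As far as these compounds go, whether a bigger group at this same carbon, such as chloro or methoxy, would give a clear step remains open. So does the result of fluoro on another carbon of this ring.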